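Bromoacrylamide chalcones: a second methoxy on the aryl ring

The compounds below may be only part of what the source reports. "The series", "measured", "known", "first", "only" and "open" are said of these compounds alone.

Measured so far:
- compound 1, `C=C(Br)C(=O)Nc1ccc(/C=C/C(=O)c2ccccc2)cc1`: 3100 nM in a functional assay on MOLT-4 cells (Homo sapiens) for antiproliferative activity, with a stated time of 48 h; on this read-out lower numbers stand for stronger inhibition and higher numbers for weaker inhibition
- compound 2, `C=C(Br)C(=O)Nc1ccc(/C=C/C(=O)c2ccc(OC)cc2)cc1`: 1300 nM
- compound 3, `C=C(Br)C(=O)Nc1ccc(C(=O)/C=C/c2cccc(OC)c2)cc1`: 1100 nM

Compounds 1 and 2 share one core; compound 3 carries another, and the difference between the two cores is not broken down here. Within the first core, the change methoxy in place of hydrogen on an aromatic carbon gives a 2.4-fold lower number from compound 1 to compound 2 (0.38 log units; beyond the scatter). Compound 3 and compound 2 sit within the scatter of each other, while compound 3 sits beyond the scatter from compound 1.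

Compound 4, `C=C(Br)C(=O)Nc1ccc(C(=O)/C=C/c2cc(OC)cc(OC)c2)cc1`, is not yet measured. It differs from compound 3 by methoxy in place of hydrogen on an aromatic carbon, the same kind of change as that from compound 1 to compound 2, but at a different place: here the entering methoxy sits meta to a large group and meta to a methoxy group, whereas in compound 2 it sits para to a large group. For the measured compounds named here, the expected step is a 1.6-fold lower number from compound 3 to compound 4 (0.20 log units; within the scatter), smaller than the earlier one because a 2.4-fold lower number from compound 1 to compound 2 (0.38 log units; beyond the scatter) is the only comparable step and was measured at a different place. Compound 4 is thus expected to give about 700 nM, plausibly between 300 nM and 2000 nM.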

Compound 4, half-maximal inhibitory concentration: 1500 nM
Compound 4: middle estimate off by 2.1-fold (0.33 log units), on the low side; the measured number falls inside the stated range.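

In this assay the entering methoxy, meta to a large group and meta to a methoxy group, gives a 1.4-fold higher number from compound 3 to compound 4 (0.13 log units; within the scatter) and so brings no change that can be told from the scatter. For the compounds shown here, this does not show that methoxy is without effect everywhere on the core of compound 3: only one place on that core is read here, and the earlier step was read at a different place, so the role of the core cannot be separated from the role of the place. What does hold is that the step read on the core of compound 1 does not carry over as a fixed increment to this place on the core of compound 3: the same change on two cores in this assay, a 2.4-fold lower number (0.38 log units; beyond the scatter) from compound 1 to compound 2 and a 1.4-fold higher number (0.13 log units; within the scatter) from compound 3 to compound 4, 3.3-fold (0.51 log units) apart, beyond the scatter of two such steps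

Still open, going by these compounds, is how the same methoxy change behaves when it enters at the same place on both cores. Also open, on these data alone, is whether a different group at this place, such as an amine, a carboxylic acid or a longer alkoxy chain, would move the number beyond the scatter.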